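Branching the amide chain of a bicyclic receptor agonist

This account rests on a few compounds, and the source may have more. Where it says the series, first, only, none or still open, it means among the compounds named here.

Three compounds share one saturated bicyclic core carrying an amide. Compound 1 `O=C(c1ccco1)[C@H]1C[C@@H]2CNC[C@@H](C2)C1` bears a furan ketone instead and has no result in an assay on SHEP1 cells for agonist activity at Neuronal acetylcholine receptor; alpha4/beta2 (Homo sapiens), read by FLIPR and calcium flux (a higher number here means a larger maximal response, a lower number a smaller maximal response), where compound 1 gives "not determined" (no result reported). Compound 2 `CNC(=O)[C@H]1C[C@@H]2CNC[C@@H](C2)C1` carries a methyl amide, and in this assay compound 2 gives 65%. Compound 3 `CCCNC(=O)[C@H]1C[C@@H]2CNC[C@@H](C2)C1` carries a propyl amide, and in this assay compound 3 gives 54%. For the measured compounds named here, of the two numbers known, compound 3 stands lowest; the only measured step, a number 11 percentage points lower from compound 2 to compound 3 (beyond the scatter), shows that growing the chain lowered the maximal response beyond the scatter.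

Compound 4 `CC(C)NC(=O)[C@H]1C[C@@H]2CNC[C@@H](C2)C1` differs from compound 3 by isopropyl in place of propyl on an amide-type nitrogen. No measured step tests a branched against a straight chain of the same size, so nothing shown points to a shift in either direction. The maximal response of compound 4 is therefore expected to stay close to that of compound 3, with a number 2 percentage points lower from compound 3 to compound 4 (within the scatter) expected to lie within the scatter, giving an estimate of 52% for compound 4, within 36% to 68%.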

Compound 4, largest response reached (Emax), in percent of the reference or control that the assay uses: 64%
Estimate against measurement, compound 4: 12 percentage points below, and the stated range covers the measured number.
By their numbers in this assay, from the lowest: compounds 3, 4 and 2 (each within the scatter of the next, the first and the last beyond it).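

In this assay, exchanging propyl for isopropyl on the amide-type nitrogen joins the same atoms differently and gives a number 10 percentage points higher from compound 3 to compound 4 (within the scatter), so at this position the branched and straight chains cannot be told apart. The step of a number 1 percentage points lower from compound 2 to compound 4 (within the scatter) adds that isopropyl also cannot be told apart from methyl, so a chain of 3 carbon atoms here does not by itself set the response apart from methyl, as the propyl of compound 3 alone might have suggested. Nothing measured alongside these numbers accounts for them.

On these data alone, whether a longer chain such as butyl, or a more heavily branched group such as tert-butyl, would stay within the same range remains open. So does the effect of replacing the amide hydrogen with a second methyl group.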